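Lengthening the amine chain from compound 3 to compound 4

The source may report more compounds than this note shows. Statements on the series, on what has been measured and on what is new or still open speak of the compounds shown alone.

In a functional assay on PC-3 cells (Homo sapiens) for antiproliferative activity, read by WST assay, with a stated time of 3 days (on this read-out higher numbers stand for weaker inhibition and lower numbers for stronger inhibition), the measured compounds read as follows:
Compound 1 `CCCOc1c(-c2cc(OC)c(OC)c(OC)c2)oc2ccccc2c1=O` gives 11800 nM
Compound 2 `CCCCCOc1c(-c2cc(OC)c(OC)c(OC)c2)oc2ccccc2c1=O` gives 22200 nM
Compound 3 `CCN(CC)CCCOc1c(-c2cc(OC)c(OC)c(OC)c2)oc2ccccc2c1=O` gives 13600 nM

Compound 3 gives 13600 nM in this assay and cannot be told apart from the other two compounds, with a 1.2-fold higher number from compound 1 to compound 3 (0.06 log units; within the scatter) and a 1.6-fold lower number from compound 2 to compound 3 (0.21 log units; within the scatter) as its steps. Repeat measurements alone could produce gaps of this size.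

The next compound, compound 4 `CCN(CC)CCCCOc1c(-c2cc(OC)c(OC)c(OC)c2)oc2ccccc2c1=O`, differs from compound 3 by one change in the side chain: (diethylamino)methyl in place of diethylamino on a saturated chain carbon, three bonds along the chain from an oxygen on an aromatic ring. Cut one bond further out, the same change reads 3-(diethylamino)propyl to 4-(diethylamino)butyl.

For the measured compounds named here, no measured pair makes exactly this change, so the evidence is indirect. The closest comparison is a 1.9-fold higher number from compound 1 to compound 2 (0.27 log units; within the scatter) where ethyl takes the place of hydrogen on the chain, and that step also stays within the scatter. Among these three compounds, then, no change to the chain has moved the number beyond the noise.

The expected step, a 1.1-fold higher number from compound 3 to compound 4 (0.04 log units; within the scatter) by this estimate, is therefore none beyond the scatter and has no clear direction. For compound 4 the expected value is 15000 nM with an estimated range from 7500 nM to 30000 nM around it.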

Compound 4, half-maximal inhibitory concentration: 13700 nM
Beside the measured number, compound 4's estimate is 1.1-fold (0.04 log units) above it; the measured number falls inside the stated range.
By their numbers in this assay, from the lowest: compounds 1, 3, 4 and 2 (each within the scatter of the next).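

In this assay, for the compounds shown here, the change from 3-(diethylamino)propyl to 4-(diethylamino)butyl gives a 1.0-fold higher number from compound 3 to compound 4 (0.00 log units; within the scatter) and so provides the first direct reading of this chain length with the diethylamino group kept at the chain end. The comparisons with the chains that carry no amine, a 1.6-fold lower number from compound 2 to compound 4 (0.21 log units; within the scatter) and a 1.2-fold higher number from compound 1 to compound 4 (0.06 log units; within the scatter), are also within the scatter, so among these four compounds neither lengthening the amine chain nor having a diethylamino group on it separates the numbers. No independent measurement bears on this result, so the close agreement of these numbers stands as an observation without an explanation.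

The compounds shown leave open whether a different amine at the chain end, such as a piperidine or morpholine ring, or a carboxylic acid in the same place, would move the number beyond the scatter. They also leave open whether a shorter 2-(diethylamino)ethyl chain or a longer chain than 4-(diethylamino)butyl on the shared core would read any differently.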